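The source may report more compounds than this note shows. Statements on the series, on what has been measured and on what is new or still open speak of the compounds shown alone.

Measured in a functional assay on HeLa cells (Homo sapiens) for cytotoxicity, read by sulforhodamine B assay, with a stated time of 48 h; a lower number here means a stronger inhibitor of growth, a higher number a weaker inhibitor of growth:
- compound 1 `Cc1nn(-c2ccccc2)c(Oc2ccc(-c3nc4cc([N+](=O)[O-])ccc4[nH]3)cc2)c1/C=N/Nc1ccccc1`: 20200 nM
- compound 2 `Cc1nn(-c2ccccc2)c(Oc2ccc(-c3nc4cc([N+](=O)[O-])ccc4[nH]3)cc2)c1/C=N/NC(N)=O`: 11700 nM

Among the measured compounds shown here, compound 2, at 11700 nM, lies within the scatter of compound 1, the only other measured compound. Compound 3 `Cc1nn(-c2ccccc2)c(Oc2ccc(-c3nc4cc([N+](=O)[O-])ccc4[nH]3)cc2)c1/C=N/NC(N)=S` differs from compound 2 in one place: a group of 3 heavy atoms (1 carbon, 1 nitrogen, 1 sulfur; no ring) in place of a group of 3 heavy atoms (1 carbon, 1 nitrogen, 1 oxygen; no ring), on an amine nitrogen. For the measured compounds named here, one measured step bears on this same amine nitrogen: a 1.7-fold lower number from compound 1 to compound 2 (0.24 log units; within the scatter). That step is within the scatter, and it exchanged a different group, so it offers only weak guidance. The estimated step is a 1.2-fold lower number from compound 2 to compound 3 (0.07 log units; within the scatter), so no change beyond the scatter is expected in this assay. Compound 3 is expected at 10000 nM, with an estimated range of 3000 nM to 25000 nM.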

Compound 3, concentration for 50% growth inhibition: 6600 nM
The estimate for compound 3 lay 1.5-fold (0.18 log units) above the measured number; low and high end bracket the measured number.
By their numbers in this assay, from the lowest: compounds 3, 2 and 1 (each within the scatter of the next, the first and the last beyond it).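

In this assay, putting sulfur in place of the carbamoyl oxygen on this amine nitrogen gives a 1.8-fold lower number from compound 2 to compound 3 (0.25 log units; within the scatter) and so does not separate the two compounds. Among the compounds shown here, replacing the phenyl group with the sulfur-bearing group, however, gives a 3.1-fold lower number from compound 1 to compound 3 (0.49 log units; beyond the scatter) and is the first step at this position to clear the scatter, if only modestly. No measurement on hand accounts for this difference. Still open, as far as these compounds go, is whether a methyl group, an acetyl group or a longer chain on this nitrogen would shift the number further.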